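Chlorophenyl urea on a trifluoromethyl-bearing core

The source may hold more compounds than are shown below. What is called first, only, known or untested is meant among the compounds shown, and "the series" means these compounds.

Of the compounds shown here, three from this series have been measured in an assay on isolated protein for inhibition of serine/threonine-protein kinase PLK1 (Homo sapiens), read by radiometric assay and 33P incorporation, with a stated time of 40 min, tested at 20 uM, in the presence of a further agent that is not named here; a higher number here means more inhibition at the concentration tested (going by the name of the read-out), a lower number less inhibition. Compound 1 `CCNc1cc(-c2ccc(NC(=O)Nc3ccc(C)cc3)cc2C)ccn1` gives 47.5% in this assay. Compound 2 `CCNc1cc(-c2ccc(NC(=O)Nc3cccc(Cl)c3)cc2C)ccn1`, which differs by 3-chlorophenyl in place of 4-methylphenyl on an amide-type nitrogen, gives 82.7%; the step of a number 35.2 percentage points higher from compound 1 to compound 2 (beyond the scatter). Compound 3 `CCNc1cc(-c2ccc(NC(=O)Nc3ccc(C)cc3)cc2C(F)(F)F)ccn1` differs from compound 1 by trifluoromethyl in place of methyl on an aromatic carbon. In this assay compound 3 gives 42.6%; here the step of a number 4.9 percentage points lower from compound 1 to compound 3 (within the scatter), so compound 1 and compound 3 cannot be told apart on this evidence.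

Compound 4 `CCNc1cc(-c2ccc(NC(=O)Nc3cccc(Cl)c3)cc2C(F)(F)F)ccn1` has not yet been measured in this assay. It differs from compound 3 by 3-chlorophenyl in place of 4-methylphenyl on an amide-type nitrogen. This is the same change that turns compound 1 into compound 2, made here on the core of compound 3, which differs from the core of compound 1 by trifluoromethyl in place of methyl on an aromatic carbon. Going by the values given here, since the step of a number 4.9 percentage points lower from compound 1 to compound 3 (within the scatter) stayed within the scatter, the trifluoromethyl-bearing core behaved like the methyl-bearing one in the single comparison available, and the same change is therefore expected to give a step of roughly the same size: a number 34.4 percentage points higher from compound 3 to compound 4 (beyond the scatter), against the measured a number 35.2 percentage points higher from compound 1 to compound 2 (beyond the scatter). On that basis compound 4 is estimated to give 77% in this assay, with a likely range from 60% to 90%. This rests on one pair alone, so a smaller or larger step would not be surprising.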

Compound 4, a percentage reported as inhibition, at one concentration (the size of the read-out at that concentration, not a potency): 94.9%
Compound 4: the middle estimate sits 17.9 percentage points below what was measured; the whole stated range lies below it.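

In this assay the change from 4-methylphenyl to 3-chlorophenyl raises the number on both cores, with a number 52.3 percentage points higher from compound 3 to compound 4 (beyond the scatter), but the size of the step does not carry over unchanged from the methyl-bearing core to the trifluoromethyl-bearing one: the same change on two cores in this assay, a number 35.2 percentage points higher (beyond the scatter) from compound 1 to compound 2 and a number 52.3 percentage points higher (beyond the scatter) from compound 3 to compound 4, 17.1 percentage points apart, beyond the scatter of two such steps

Seen from the other side, trifluoromethyl in place of methyl gives a number 12.2 percentage points higher from compound 2 to compound 4 (beyond the scatter), although the same swap left no readable difference with 4-methylphenyl on the amide-type nitrogen: the same change on two cores in this assay, a number 4.9 percentage points lower (within the scatter) from compound 1 to compound 3 and a number 12.2 percentage points higher (beyond the scatter) from compound 2 to compound 4, 17.1 percentage points apart, beyond the scatter of two such steps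

So the two changes do not simply add up across these compounds, yet this is one set of four compounds at a single concentration, which shows neither a difference in potency nor whether the same holds elsewhere in the series.

The compounds shown leave open whether the larger step would recur with a nitrile or a chlorine in place of the trifluoromethyl. They also leave open what a pyridine ring in place of the 3-chlorophenyl, or a longer chain in place of the ethyl group, would do.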